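A few compounds are considered here, and "the series" means these few. Any claim that something is new, unique, unknown or untested is made for them only; others in the source may bear on it.

Measured compounds and their values:

Compound 1 `N#Cc1ccc(Cn2cc(C[C@H](O)COCCOC[C@@H](O)Cc3ccc(-c4ccccc4)cc3)nn2)cc1` — 7700 nM
Compound 2 `O[C@H](COCCOC[C@@H](O)Cc1cn(-c2cccs2)nn1)Cc1ccc(-c2ccccc2)cc1` — 33400 nM
Compound 3 `O=c1[nH]c2ccc(-n3cc(C[C@H](O)COCCOC[C@@H](O)Cc4ccc(-c5ccccc5)cc4)nn3)cc2s1` — 10500 nM

All three were tested in a functional assay on SGC-7901 cells (Homo sapiens) for inhibition, read by MTT assay, with a stated time of 72 h; on this read-out higher numbers stand for weaker inhibition of growth and lower numbers for stronger inhibition of growth. Compound 3 sits second highest of the three numbers: its value is close to that of compound 1, since a 1.4-fold higher number from compound 1 to compound 3 (0.13 log units; within the scatter), while it is clearly set apart from compound 2, since a 3.2-fold lower number from compound 2 to compound 3 (0.50 log units; beyond the scatter). Compound 2 gives the highest number, and a 4.3-fold higher number from compound 1 to compound 2 (0.64 log units; beyond the scatter).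

Compound 4 `O[C@H](COCCOC[C@@H](O)Cc1cn(-c2ccc3[nH]ccc3c2)nn1)Cc1ccc(-c2ccccc2)cc1` has not been measured. It differs from compound 3 only on the aromatic nitrogen of the shared core: a group of 9 heavy atoms (8 carbon, 1 nitrogen; one five-membered aromatic ring with 1 hetero atom, one six-membered aromatic ring of carbon only) in place of a group of 10 heavy atoms (7 carbon, 1 nitrogen, 1 oxygen, 1 sulfur; one five-membered aromatic ring with 2 hetero atoms, one six-membered aromatic ring of carbon only), on an aromatic nitrogen.

Going by the values given here, two measured steps bear on this swap. The exchange of one aromatic group for another on the same nitrogen went both ways: a 1.4-fold higher number from compound 1 to compound 3 (0.13 log units; within the scatter), and a 3.2-fold lower number from compound 2 to compound 3 (0.50 log units; beyond the scatter). Among the compounds with values here, the incoming 1H-indol-5-yl, like the group it replaces, keeps a six-membered aromatic ring of carbon only fused to a five-membered aromatic ring and keeps one hydrogen-bond donor, which is closer to what compound 1 and compound 3 share than to the single five-membered ring of compound 2. The step in this assay is therefore expected to be small, with no firm direction, an estimate of a 1.1-fold lower number from compound 3 to compound 4 (0.02 log units; within the scatter).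

Compound 4 is accordingly estimated at 10000 nM, with a range from 4000 nM to 25000 nM.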

Compound 4, concentration for 50% growth inhibition: 45600 nM
Estimate against measurement, compound 4: 4.6-fold (0.66 log units) below; the measured number lies above the stated range.
By their numbers in this assay, from the lowest: compounds 1 and 3 (each within the scatter of the next); then compounds 2 and 4 (each within the scatter of the next).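

In this assay, the swap shows that a matching outline is not enough at this nitrogen of the triazole-type ring: 1H-indol-5-yl and the group it replaces each join a five-membered aromatic ring to a six-membered aromatic ring of carbon only and each carry 1 hydrogen-bond donor, yet the change is beyond the scatter (a 4.3-fold higher number from compound 3 to compound 4 (0.64 log units; beyond the scatter)). Ring count does not sort these groups either, since two-ring 1H-indol-5-yl stays within the scatter of single-ring thiophen-2-yl (a 1.4-fold higher number from compound 2 to compound 4 (0.14 log units; within the scatter)) but is clearly set apart from 4-cyanobenzyl (a 5.9-fold higher number from compound 1 to compound 4 (0.77 log units; beyond the scatter)). The clearest remaining difference in this pair is that the leaving group has 2 hydrogen-bond acceptors and a double bond outside the aromatic rings, while 1H-indol-5-yl has neither, though this single pair cannot show that those features matter.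

Nothing available here explains the size of this step. On these data alone, it also remains open whether a carbonyl, a carboxylic acid or an amine added to 1H-indol-5-yl would bring the number back toward that of compound 3.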